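Compound 2 to compound 3: an added isopropyl

The source may report more compounds than this note shows. Statements on the series, on what has been measured and on what is new or still open speak of the compounds shown alone.

In a functional assay on ID8 cells (Mus musculus) for antiproliferative activity (a higher number here means a weaker inhibitor, a lower number a stronger inhibitor), compound 1 (`O=C(Nc1ccc(O)c2c(=O)cc(-c3ccccc3Cl)oc12)c1ccccc1`) gives 13000 nM, while compound 2 (`C[C@@H](NC(=O)OC(C)(C)C)C(=O)Nc1ccc(O)c2c(=O)cc(-c3ccccc3Cl)oc12`) gives 104000 nM, the higher of the two numbers and thus the weaker inhibitor. Compound 3 (`CC(C)C[C@@H](NC(=O)OC(C)(C)C)C(=O)Nc1ccc(O)c2c(=O)cc(-c3ccccc3Cl)oc12`) differs from compound 2 by a single change, isopropyl in place of hydrogen on a saturated chain carbon, two bonds along the chain from an amide-type nitrogen and a carbonyl carbon.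

Among the measured compounds shown here, only one measured step bears on this, and only indirectly: an 8.0-fold higher number from compound 1 to compound 2 (0.90 log units; beyond the scatter), modest but beyond the scatter, replaced the whole group on the carbonyl carbon. For the measured compounds named here, no measured step alters this chain carbon, so no direction can be drawn from the data. The expected change is small, a 1.3-fold lower number from compound 2 to compound 3 (0.11 log units; within the scatter), with no step beyond the scatter anticipated in this assay. Compound 3 is expected at 80000 nM, with an estimated range of 25000 nM to 250000 nM.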

Compound 3, half-maximal inhibitory concentration: 17000 nM
For compound 3 the middle estimate is 4.7-fold (0.67 log units) above the measured one, outside the stated range (below it).
By their numbers in this assay, from the lowest: compounds 1 and 3 (each within the scatter of the next); then compound 2.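

In this assay, the saturated chain carbon two bonds along the chain from an amide-type nitrogen and a carbonyl carbon responds to substitution: isopropyl in place of hydrogen gives a 6.1-fold lower number from compound 2 to compound 3 (0.79 log units; beyond the scatter). The same difference, read as methyl to isobutyl, brings compound 3 at 17000 nM within the scatter of compound 1 at 13000 nM, so the change seen in an 8.0-fold higher number from compound 1 to compound 2 (0.90 log units; beyond the scatter) does not hold for every carbamate-bearing chain on this carbonyl carbon. No supporting evidence bears on why this substitution lowers the number.

Open, on these data alone, is how the number responds to the size and type of group at this carbon, for example an ethyl, a longer chain, a phenyl or a carboxylic acid. Also open, as far as these compounds go, is whether the isobutyl effect survives when the tert-butoxycarbonyl group gives way to a free amine.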